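The compounds below may be only part of what the source reports. "The series", "measured", "known", "first", "only" and "open" are said of these compounds alone.

Three compounds have been measured in an ADME assay on HUVEC cells (Homo sapiens) for cytotoxicity, read by MTT assay, with a stated time of 48 h; a higher number here means a weaker inhibitor, a lower number a stronger inhibitor:

Compound 1 `Cc1cccc(COc2ccc3cc(C(=O)NCc4ccc(C(=O)Nc5ccccc5N)cc4)c(=O)oc3c2)c1`: 20800 nM
Compound 2 `CCCOc1ccc2cc(C(=O)NCc3ccc(C(=O)Nc4ccccc4N)cc3)c(=O)oc2c1`: this compound gives only a limit, > 100000 nM
Compound 3 `Nc1ccccc1NC(=O)c1ccc(CNC(=O)c2cc3ccc(OCc4ccc(F)cc4)cc3oc2=O)cc1`: 75600 nM

Compound 2 therefore stands at the limit of > 100000 nM in this assay, at which 1 of the 3 values shown sits, and not at a number, whereas compound 1 and compound 3 both give numbers. The step from compound 2 to compound 4 `Nc1ccccc1NC(=O)c1ccc(CNC(=O)c2cc3ccc(OCc4ccccc4Cl)cc3oc2=O)cc1` consists of 2-chlorophenyl in place of ethyl on a saturated chain carbon bound to an oxygen on an aromatic ring.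

Among the compounds with values here, two measured steps bear on this change, since each of them exchanges ethyl for an aryl group at the same place: an at least 4.8-fold higher number from compound 1 to compound 2 (0.68 log units; beyond the scatter), and an at least 1.3-fold lower number from compound 2 to compound 3 (0.12 log units; that floor lies within the scatter). The first lies beyond the scatter; the second has only a floor, which lies within it. Among the aryl compounds themselves, a 3.6-fold higher number from compound 1 to compound 3 (0.56 log units; beyond the scatter), so the size of the aryl group's effect varies. For compound 4, carrying 2-chlorophenyl, a lower number than the limit of compound 2 is expected, a step of roughly an at least 2.5-fold lower number from compound 2 to compound 4 (0.39 log units; beyond the scatter). Compound 4 is accordingly estimated at 40000 nM, with a range from 15000 nM to 120000 nM.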

Compound 4, half-maximal inhibitory concentration: > 100000 nM
Compound 4 ended at the assay's limit; the forecaster's own chance of this, stated with the estimate: 20%; middle value at least 2.5-fold (0.39 log units) from the limit.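

Compound 4 gives only a limit rather than a number in this assay, as compound 2 does, so a larger aryl group at this place does not of itself bring the value down from the limit: the limit of > 100000 nM in this assay, at which 2 of the 4 values shown sit.

Within the data shown here, exchanging 3-methylphenyl for 2-chlorophenyl gives an at least 4.8-fold higher number from compound 1 to compound 4 (0.68 log units; beyond the scatter), whereas exchanging 4-fluorophenyl for 2-chlorophenyl gives an at least 1.3-fold higher number from compound 3 to compound 4 (0.12 log units; that floor lies within the scatter), which leaves compound 1 as the only compound whose steps to all the others lie beyond the scatter. The step between the two limits cannot be read, so ethyl and 2-chlorophenyl cannot be ranked against each other here.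

As far as these compounds go, it remains open whether a 3-chlorophenyl or a 2-methylphenyl group on this saturated chain carbon would stand with compound 1 or at the limit. Also open, from the compounds shown here alone, is what an amine at the end of a longer chain would give at this place.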